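The source may hold more compounds than are shown below. What is called first, only, known or untested is meant among the compounds shown, and "the series" means these compounds.

The study sets out from compound 1, `C=CCn1c(=O)/c(=C\c2ccc(Cl)c(Cl)c2)[nH]c(=O)/c1=C\c1ccccc1OC`, which in a functional assay on MCF7 cells (Homo sapiens) for cytotoxicity, read by CCK-8 assay, with a stated time of 72 h (a lower number here means a stronger inhibitor, a higher number a weaker inhibitor), gave the result "not active" (no number reported), so no single number stands for it and its place on the scale cannot be fixed more closely than that. Its closest neighbour among the measured compounds is compound 2, `C=CCn1c(=O)/c(=C\c2ccccc2OC)[nH]c(=O)/c1=C\c1ccccc1OC`, in which the dichlorophenyl side of compound 1 is exchanged for a second 2-methoxyphenyl group; in this assay compound 2 gives 41100 nM, a weak result by any standard. The two compounds share the same core and differ only in that one aryl group, and the comparison shows that neither reaches a potency worth noting.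

The step to compound 3, `C=CCn1c(=O)/c(=C\c2ccc(Cl)c(Cl)c2)[nH]c(=O)/c1=C\c1ccccc1`, keeps the dichlorophenyl side of compound 1 and makes one change on the other side: hydrogen in place of methoxy on an aromatic carbon. Since compound 1 itself has no number, the size of this step cannot be read from the data. With compound 2 already at 41100 nM and compound 1 reported inactive, compound 3 is expected to remain weak, and a result beyond the usual scatter in either direction is not anticipated. Compound 3 is therefore estimated at 60000 nM, within a range from 15000 nM to 200000 nM, with a real chance that only a limit is reported.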

Compound 3, half-maximal inhibitory concentration: "not active" (no number reported)
The entry for compound 3 holds no number, so the estimate cannot be set against anything.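

In this assay, among the compounds shown here, compound 3 gives "not active" (no number reported), as compound 1 does, so no step between compound 1 and compound 3 can be read. The compounds shown leave open how far the change from 2-methoxyphenyl to phenyl moves potency and where either compound lies on the scale. No supporting evidence bears on this result.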